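The source may hold more compounds than are shown below. What is called first, only, known or untested is meant among the compounds shown, and "the series" means these compounds.

Measured so far:
compound 1, `O/N=C(\CCN1CCN(c2ccccn2)CC1)c1cccc(Cl)c1`, in a functional assay on HEK293 cells with D(4) dopamine receptor (Homo sapiens) as the target, read by FLIPR (a higher number here means a larger maximal response, a lower number a smaller maximal response), gives 73%
compound 2, `Cc1cccc(/C(CCN2CCN(c3ccccn3)CC2)=N/O)c1`, in this assay gives 74%

Within the data shown here, compound 2 holds the higher of the two numbers, yet its only neighbour is compound 1, and the step between them, a number 1 percentage points higher from compound 1 to compound 2 (within the scatter), does not reach beyond the scatter. On these two numbers compound 2 therefore stands level with compound 1 rather than above it.

Compound 3, `Cc1cccc(/C(=N/O)C(O)CN2CCN(c3ccccn3)CC2)c1`, keeps everything in compound 2 and adds one group: hydroxy in place of hydrogen on a saturated chain carbon bound to a carbon with a double bond to nitrogen and a saturated chain carbon.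

Among the measured compounds shown here, the one measured step, from compound 1 to compound 2, swaps a group on an aromatic carbon and leaves the chain untouched; it says nothing about what a hydroxy on that chain carbon does, and no other pair of measured compounds is available. For the measured compounds named here, there is thus no measured step that bears on this change. With no guide, the expectation rests on compound 2 alone, and the estimated step of a number 4 percentage points lower from compound 2 to compound 3 (within the scatter) is set at none beyond the scatter, with a wide range to allow for the unknown.

For compound 3 the estimated value in this assay is 70%, between 45% and 90%.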

Compound 3, largest response reached (reported as efficacy), in percent of the reference or control that the assay uses: 81%
The estimate for compound 3 lay 11 percentage points below the measured number; low and high end bracket the measured number.
By their numbers in this assay, from the lowest: compounds 1, 2 and 3 (each within the scatter of the next).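

Among these compounds, compound 3 is the first compound here changed on the chain rather than on an aromatic carbon, and in this assay this change gives a number 7 percentage points higher from compound 2 to compound 3 (within the scatter). Compound 3 therefore stands level with compound 2, which shows that this saturated chain carbon can carry a hydroxy in place of hydrogen with no loss of maximal response beyond the usual variation between repeated measurements; a single added group on the chain is enough to show this for the hydroxy, though not for any other group. Nothing available explains why the response holds at this position.

From the compounds shown here alone, what a methoxy, a fluorine or a methyl on the same chain carbon would do remains open, as does whether a hydroxy there gives a similar result when the chloro of compound 1 sits on the aromatic carbon in place of the methyl. Also open, going by these compounds, is how much of each compound is needed to reach its maximal response, since a maximal response alone does not tell how potent a compound is.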